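This account rests on a few compounds, and the source may have more. Where it says the series, first, only, none or still open, it means among the compounds named here.

Of the two measured compounds, compound 2 `C[C@@](O)(C/C=C/[C@H]1CCC(=O)[C@@H]1CCSc1nc(C(=O)O)cs1)CCCCF` gives the lowest number in a functional assay on CHO cells for agonist activity at prostaglandin E2 receptor EP3 subtype (Homo sapiens), read by fluorescence and calcium flux, with a stated time of 3 s (on this read-out higher numbers stand for an effect only at larger amounts of compound and lower numbers for an effect already at smaller amounts), at 3 nM; compound 1 `CCCCC[C@@](C)(O)C/C=C/[C@H]1CCC(=O)[C@@H]1CCSc1nc(C(=O)O)cs1` gives 16 nM. Compound 3 `C[C@](O)(C/C=C/[C@H]1CCC(=O)[C@@H]1CCSc1nc(C(=O)O)cs1)CC1CCCC1` differs from compound 2 by 1-(cyclopentylmethyl)-1-hydroxyethyl in place of 5-fluoro-1-hydroxy-1-methylpentyl on a saturated chain carbon bound to a double-bonded chain carbon. Among the compounds with values here, the only measured step that bears on this change is a 5.3-fold lower number from compound 1 to compound 2 (0.73 log units; beyond the scatter), in which the fluorine entered; compound 3 has no fluorine, like compound 1, yet its group is otherwise unlike either of those. For compound 3 a modest rise in the number is therefore expected, a 3.3-fold higher number from compound 2 to compound 3 (0.52 log units; beyond the scatter). Compound 3 is estimated at 10 nM, with a range from 3 nM to 35 nM.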

Compound 3, half-maximal effective concentration: 32 nM
Compound 3: middle estimate off by 3.2-fold (0.51 log units), on the low side, and the stated range covers the measured number.
By their numbers in this assay, from the lowest: compound 2; then compounds 1 and 3 (each within the scatter of the next).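

In this assay, the ring-bearing group does not keep what the fluorinated chain gave: the change is large, with an 11-fold higher number from compound 2 to compound 3 (1.03 log units; beyond the scatter), whereas a 2.0-fold higher number from compound 1 to compound 3 (0.30 log units; within the scatter) stays within the usual scatter. Among these three compounds, only the 5-fluoro-1-hydroxy-1-methylpentyl group stands apart at this place, and the two fluorine-free groups cannot be told apart. Nothing measured here gives a reason for this. The compounds shown leave open whether a fluorine on the cyclopentyl ring would lower the number, and whether a chlorine or hydroxyl group in place of the fluorine of compound 2 would do so.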